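Triazole-linked cinnamic acid series: amide for methoxy

The source may report more compounds than this note shows. Statements on the series, on what has been measured and on what is new or still open speak of the compounds shown alone.

For the measured compounds named here, compound 1 `COc1ccccc1-n1cc(COc2c(/C=C\C(=O)O)ccc(OC)c2CC=C(C)C)nn1` is the one member of this set with a number: in a functional assay on COLO 205 cells (Homo sapiens) for cytotoxicity, read by MTT assay, with a stated time of 24 h (a lower number here means a stronger inhibitor, a higher number a weaker inhibitor), compound 1 gives 12200 nM. Going by the values given here, compound 2 `COc1cccc(-n2cc(COc3c(/C=C\C(=O)O)ccc(OC)c3CC=C(C)C)nn2)c1`, which carries the methoxy on a different aromatic carbon, has no number here: in this assay compound 2 is reported only as "not determined" (no result reported), so compound 1 stands alone and no comparison between measured compounds is available.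

Compound 3 `COc1ccc(/C=C\C(=O)O)c(OCc2cn(-c3ccccc3C(=O)N3CCC(O)C3)nn2)c1CC=C(C)C` is the untested analogue. It differs from compound 1 in one place: (3-hydroxypyrrolidin-1-yl)carbonyl in place of methoxy on an aromatic carbon, ortho to a large group.

Among the compounds with values here, with no measured step to lean on, the expectation rests on compound 1 alone, and the step from compound 1 to compound 3 is expected to be small, a 1.1-fold lower number from compound 1 to compound 3 (0.04 log units; within the scatter), with no clear direction beyond the usual scatter. Compound 3 is therefore estimated at 11000 nM, with the range 3500 nM to 35000 nM in this assay, and a real chance that a weak compound at this level is reported only as a limit.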

Compound 3, half-maximal inhibitory concentration: 25400 nM
The estimate for compound 3 lay 2.3-fold (0.36 log units) below the measured number, within the range that was stated.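

In this assay, for the compounds shown here, the first readable step is a 2.1-fold higher number from compound 1 to compound 3 (0.32 log units; beyond the scatter) and it comes from putting (3-hydroxypyrrolidin-1-yl)carbonyl in place of methoxy on an aromatic carbon, ortho to a large group. The step is modest but beyond the scatter, so this position is not indifferent to the change, and the direction is towards a weaker compound. At the same time, a group of 8 heavy atoms with a five-membered non-aromatic ring, in place of one of 2 heavy atoms, still gives a measured number rather than a limit, and no measurement shown here accounts for the size of the step.

The compounds shown do not separate the contribution of the hydroxyl from that of the amide carbonyl or the ring; the unsubstituted pyrrolidin-1-ylcarbonyl group, a dimethylamide or a carboxylic acid on this carbon would address that. Going by these compounds alone, whether the same step holds on any other member of the series also remains open, as this single pair is the only reading at this position.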